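A few compounds are considered here, and "the series" means these few. Any claim that something is new, unique, unknown or untested is made for them only; others in the source may bear on it.

Measured compounds:
- compound 1, `COc1ccc(Cn2cc(C(N)=O)c3c(N)ncnc32)cc1`: 47000 nM
- compound 2, `N#Cc1cn(Cc2ccccc2)c2ncnc(N)c12`: > 100000 nM

Both were tested in a functional assay on KB cells (Homo sapiens) for cytotoxicity; a lower number here means a stronger inhibitor, a higher number a weaker inhibitor. Compound 1 carries a primary amide on the shared core together with a methoxy group, and in this assay compound 1 gives 47000 nM, a weak result. Compound 2 carries a nitrile instead and no methoxy group. For compound 2 the result is only a limit, > 100000 nM, not a number. Compound 2 therefore stands at the limit of > 100000 nM in this assay, at which 1 of the 2 values shown sits, the weaker end of what is shown, and the two values say only that compound 1 was measured while compound 2 was not resolved.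

Compound 3, `COc1ccc(Cn2cc(C#N)c3c(N)ncnc32)cc1`, is the nitrile counterpart with the same methoxy group as compound 1. Relative to compound 2 the change is methoxy in place of hydrogen on an aromatic carbon. Within the data shown here, no measured pair tracks this change, so the expected step of an at least 1.1-fold lower number from compound 2 to compound 3 (0.04 log units; that floor lies within the scatter) is none beyond the scatter, and the result may well again be a limit. Compound 3 is expected at 90000 nM, within a range from 30000 nM to 250000 nM.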

Compound 3, half-maximal inhibitory concentration: > 100000 nM
Compound 3: no number, only a limit; the forecaster's own chance of this, stated with the estimate: 60%; middle value at least 1.1-fold (0.04 log units) away from the limit.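

With the methoxy group held fixed, cyano in place of carbamoyl on an aromatic carbon gives an at least 2.1-fold higher number from compound 1 to compound 3 (0.32 log units; beyond the scatter) in this assay, which gives the change at this position a direction, though only a minimum size. In this assay compound 3 gives > 100000 nM, which is a limit and not a number, so the true size of the step may be larger than the printed minimum. The step for methoxy in place of hydrogen on the aromatic ring, para to a large group, cannot be read, and with this nitrile pair the series now gathers at the top of the range of the assay: the limit of > 100000 nM in this assay, at which 2 of the 3 values shown sit.

What methoxy does in this assay therefore remains unknown for the nitrile compounds, and the compounds shown offer no amide partner without methoxy that could test it on the amide side. On these data alone, it also remains open whether another group in place of the carbamoyl, such as a carboxylic acid, a methyl ester or an aminomethyl group, would give a lower number than compound 1 does at 47000 nM.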